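The source may hold more compounds than are shown below. What is called first, only, known or untested is meant among the compounds shown, and "the series" means these compounds.

Notes on a small set of compounds sharing a core, assessed in an ADME assay on microsomes from liver (Mus musculus) for metabolic stability, read by LC-MS, with NADPH named in the record, with a stated time of 60 min, tested at 1 uM, in the absence of a further agent; a higher number here means that more of the compound is left, a lower number that less of the compound is left.

Within the data shown here, compound 1, `COc1ccc(-n2c(C)nc3c(N4CC[C@@H](NC(C)=O)C4)nc(C)nc32)cc1OC`, is the first member. In this assay compound 1 gives > 95%, which is a limit of the assay rather than a number. Compound 2, `CC(=O)N[C@@H]1CCN(c2cc(C)nn3c(-c4ccc5cc[nH]c5c4)c(C)nc23)C1`, is the second member. In this assay compound 2 gives > 95%, again a limit. Compound 3, `COc1ccc(-c2c(C)nc3c(N4CC[C@@H](NC(=O)OC5CCCCC5)C4)cc(C)nn23)cc1OC`, is the third member. In this assay compound 3 gives > 95%, also a limit. Among the measured compounds shown here, compound 3 thus stands where the whole set stands, since (the limit of > 95% in this assay, at which 3 of the 3 values shown sit); no member sits below it and no ordering among the three can be drawn from these values.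

Compound 4, `COc1ccc(-c2c(C)nc3c(N4CC[C@@H](NS(=O)(=O)c5cccs5)C4)cc(C)nn23)cc1OC`, is not yet measured. It differs from compound 3 in one place: (thiophen-2-yl)sulfonyl in place of cyclohexyloxycarbonyl on an amine nitrogen.

For the measured compounds named here, no step between measured compounds is available, so the size of a change at this amine nitrogen in this assay cannot be read from the set itself. Since (the limit of > 95% in this assay, at which 3 of the 3 values shown sit), compound 4 is expected to remain near that limit, and the step from compound 3 to compound 4 is estimated as a number at least 5 percentage points lower from compound 3 to compound 4 (that floor lies within the scatter), a size within the usual scatter. For compound 4 in this assay the estimate is 90%, between 72% and 98%.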

Compound 4, percent of the compound remaining: > 95%
Compound 4: only a limit was reported; the forecaster's own chance of this, stated with the estimate: 50%; middle value at least 5 percentage points away from the limit.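

In this assay compound 4 gives > 95%, which is a limit of the assay. Among these compounds, compound 3 also stands at a limit, so no step from compound 3 to compound 4 can be read. The compounds shown leave open what a change on this amine nitrogen does to the percent remaining, because no member can be ordered against another: the limit of > 95% in this assay, at which 4 of the 4 values shown sit.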